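The source may hold more compounds than are shown below. What is called first, only, known or untested is meant among the compounds shown, and "the series" means these compounds.

Measured so far:
compound 1, `CCCCCCCCCCC[C@@H](C[C@@H]1OC(=O)[C@H]1CCCCCC)OC(=O)[C@H](CC(C)C)NC(=O)OC(C)(C)C`, in an assay on membranes from brain for inhibition of Fatty-acid amide hydrolase 1 (Rattus norvegicus); a lower number here means a stronger inhibitor, a higher number a weaker inhibitor: > 50000 nM
compound 2, `CCCCCCCCCCC[C@@H](C[C@@H]1OC(=O)[C@H]1CCCCCC)OC(=O)CCC(C)C`, in this assay: 10400 nM

For the measured compounds named here, compound 2 is the only member with a real number; in this assay compound 2 gives 10400 nM. For compound 1 the value > 50000 nM is a limit of the assay, not a number. Going by the values given here, the single measured step is an at least 4.8-fold lower number from compound 1 to compound 2 (0.68 log units; beyond the scatter), where compound 1 sits at the limit of > 50000 nM in this assay, at which 1 of the 2 values shown sits, and the removal of the (tert-butoxycarbonyl)amino brings the number down to that of compound 2.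

Compound 3, `CCCCCCCCCCC[C@@H](C[C@@H]1OC(=O)[C@H]1CCCCCC)OC(=O)[C@H](C)NC=O`, is still to be measured. Against compound 2 the change is a group of 5 heavy atoms (3 carbon, 1 nitrogen, 1 oxygen; no ring) in place of a group of 5 heavy atoms (5 carbon; no ring), on a carbonyl carbon. The incoming group restores a hydrogen-bond donor and acceptor near the ester, as compound 1 carried on a saturated chain carbon bound to a carbonyl carbon. Among the compounds with values here, the one step that bears on this moved beyond the scatter toward a lower number when such a group was taken away; putting a related group back is therefore expected to move the other way, with an expected step of a 3.8-fold higher number from compound 2 to compound 3 (0.59 log units; beyond the scatter) toward a weaker inhibitor, possibly again at the limit. Compound 3 is estimated at 40000 nM, range 10000 nM to 160000 nM.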

Compound 3, half-maximal inhibitory concentration: > 50000 nM
Compound 3 was reported as a limit (the forecaster's own chance of this, stated with the estimate: 50%); at least 1.2-fold (0.09 log units) between middle value and limit.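

In this assay the exchange on the carbonyl carbon is an at least 4.8-fold higher number from compound 2 to compound 3 (0.68 log units; beyond the scatter), with isopentyl leaving and a group of equal heavy-atom count entering, so the loss does not track the number of heavy atoms in the group. The earlier step involved the large (tert-butoxycarbonyl)amino group, whereas this one shows that a much smaller group bearing a hydrogen-bond donor and a hydrogen-bond acceptor also goes with a weaker inhibitor than the plain isopentyl ester. Compound 3 stands at a limit of the assay, the same one as compound 1, which leaves compound 2 as the only member with a real number: the limit of > 50000 nM in this assay, at which 2 of the 3 values shown sit.

From the compounds shown here alone, compound 3 changes the donor, the acceptor and the carbon skeleton of the group together, so which of these goes with the loss stays open. A longer alkyl chain on the same carbonyl carbon would test whether this position can give numbers lower than that of compound 2, and a free amine or a carboxylic acid in the group would test whether the loss extends to charged groups.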